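This account rests on a few compounds, and the source may have more. Where it says the series, first, only, none or still open, it means among the compounds named here.

Measured in a physicochemical assay for solubility, at pH 7 (on this read-out lower numbers stand for lower solubility and higher numbers for higher solubility), so far:

Compound 1 `CN1CCC(C(=O)N2Cc3c(NC(=O)C4CC4)n[nH]c3C2(C)C)CC1` gives > 225000 nM as a limit
Compound 2 `CC(C)(C)C(=O)N1Cc2c(NC(=O)C3CCNCC3)n[nH]c2C1(C)C` gives > 225000 nM as a limit
Compound 3 `CC(C)(C)C(=O)N1Cc2c(NC(=O)c3cccnc3)n[nH]c2C1(C)C` gives 207000 nM as a number

Compound 1 has no number, only a limit: it stands at the limit of > 225000 nM in this assay, at which 2 of the 3 values shown sit, and its true place is not known.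

Compound 4 `CN1CCC(C(=O)N2Cc3c(NC(=O)NCc4ccccc4)n[nH]c3C2(C)C)CC1` has not yet been measured. It departs from compound 1 by benzylamino in place of cyclopropyl on a carbonyl carbon with benzylamino in place of cyclopropyl on a carbonyl carbon.

Within the data shown here, only one measured step bears on this change, pyridin-3-yl in place of piperidin-4-yl on a carbonyl carbon. That step is an at least 1.0-fold lower number from compound 2 to compound 3 (0.03 log units; that floor lies within the scatter) and it starts from a limit, so it offers no size to carry over.

Among the measured compounds shown here, a modest move toward a lower number in this assay is expected, though on thin ground: compound 3, the only measured compound with an aromatic ring on that carbonyl carbon, reads 207000 nM and is also the only one to give a number. The estimated step is an at least 1.8-fold lower number from compound 1 to compound 4 (0.27 log units; that floor lies within the scatter) and it starts from a limit. For compound 4 the expected value is 120000 nM with an estimated range from 30000 nM to 230000 nM and a report of only a limit remains possible.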

Compound 4, solubility: > 225000 nM
Compound 4 ended at the assay's limit; the forecaster's own chance of this, stated with the estimate: 30%; at least 1.8-fold (0.27 log units) between middle value and limit.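

In this assay compound 4 gives > 225000 nM, which is a limit. Compound 1 also stands at a limit, so no step from compound 1 to compound 4 can be read: the limit of > 225000 nM in this assay, at which 3 of the 4 values shown sit.

The compounds shown leave open whether benzylamino in place of cyclopropyl on a carbonyl carbon changes this read-out at all, and by how much.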